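Swapping the aryl amide for a cyclopropyl amide

A few compounds are considered here, and "the series" means these few. Any claim that something is new, unique, unknown or untested is made for them only; others in the source may bear on it.

Measured so far in an in vitro functional assay on HEK293-A cells for antagonist activity at metabotropic glutamate receptor 5 (Rattus norvegicus), read by calcium flux; a lower number here means a stronger inhibitor, a higher number a weaker inhibitor:
- compound 1, `COc1ccccc1C(=O)Nc1cccc(NC(=O)c2ccc(Cl)cc2)c1`: in this assay compound 1 gives > 30000 nM, which is a limit of the assay rather than a number.
- compound 2, `COc1ccccc1C(=O)Nc1cccc(NC(=O)c2cccc(F)c2)c1`: in this assay compound 2 gives 6480 nM.

Within the data shown here, compound 2 thus holds the only actual number; the one other result is a limit. Compound 3, `COc1ccccc1C(=O)Nc1cccc(NC(=O)C2CC2)c1`, has not been measured yet. It differs from compound 2 in one place: cyclopropyl in place of 3-fluorophenyl on a carbonyl carbon. Among the measured compounds shown here, only one measured step exists to lean on, and it touches the same carbonyl carbon: an at least 4.6-fold lower number from compound 1 to compound 2 (0.66 log units; beyond the scatter). That step shows that changing the group on this carbonyl carbon can shift the result by a good margin, but it compares two aromatic rings, whereas compound 3 replaces the ring with a small non-aromatic one. There is no measured evidence on how such a small group behaves here. The expectation is therefore uncertain in direction, with a weaker result somewhat more likely than a stronger one, and a sizeable chance that only a limit is reported. The step from compound 2 to compound 3 is expected to be a 2.3-fold higher number from compound 2 to compound 3 (0.36 log units; beyond the scatter). For compound 3 the estimate in this assay is 15000 nM, with a range from 4000 nM to 50000 nM.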

Compound 3, half-maximal inhibitory concentration: > 30000 nM
Compound 3: no number, only a limit (the forecaster's own chance of this, stated with the estimate: 40%); middle value at least 2.0-fold (0.30 log units) from the limit.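

In this assay, putting the smaller cyclopropyl ring in place of the aromatic 3-fluorophenyl ring on this carbonyl carbon gives an at least 4.6-fold higher number from compound 2 to compound 3 (0.66 log units; beyond the scatter). Among these compounds, the earlier step at this place compared only two aromatic rings, whereas this one shows that a small non-aromatic ring also does worse than the 3-fluorophenyl group, leaving compound 2 as the only one of the three compounds with an actual number. The step between compound 1 and compound 3 cannot be read, and the full size of the loss from compound 2 to compound 3 stays hidden, since the results for compound 1 and compound 3 are limits and not numbers: the limit of > 30000 nM in this assay, at which 2 of the 3 values shown sit.

The compounds shown cannot separate the effect of losing the aromatic ring from the effect of shrinking the group, a question that a cyclohexyl ring or an unsubstituted phenyl ring on the same carbonyl carbon could help to answer. They also leave open how a pyridine ring, a longer chain such as n-butyl, or an amine would fare at this place.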